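A few compounds are considered here, and "the series" means these few. Any claim that something is new, unique, unknown or untested is made for them only; others in the source may bear on it.

Measured compounds:
compound 1, `CN(C)C(=O)c1cc2cnc(Nc3ccc(S(=O)(=O)NCCCN=C=S)cc3)nc2n1C1CCCC1`, 102%
compound 2, `CN(C)C(=O)c1cc2cnc(Nc3ccc(C(=O)NCCCCN=C=S)cc3)nc2n1C1CCCC1`, 102%

In a functional assay on A549 cells (Homo sapiens) for inhibition, read by CCK-8 assay, with a stated time of 72 h, tested at 10 uM (on this read-out higher numbers stand for a stronger effect at the one concentration tested and lower numbers for a weaker effect), compound 2 gives 102% and stands level with compound 1, whose value is 102%. Compound 3, `CN(C)C(=O)c1cc2cnc(Nc3ccc(C(=O)NCCCCCN=C=S)cc3)nc2n1C1CCCC1`, differs from compound 2 by a group of 4 heavy atoms (2 carbon, 1 nitrogen, 1 sulfur; no ring) in place of a group of 3 heavy atoms (1 carbon, 1 nitrogen, 1 sulfur; no ring), on a saturated chain carbon, four bonds along the chain from an amide-type nitrogen. For the measured compounds named here, the only measured step, no change at the digits printed from compound 1 to compound 2 (within the scatter), swapped a whole group on the aromatic carbon without effect, so a lengthening of the chain by one carbon is expected to leave this assay unchanged beyond the scatter, with the expected step of a number 2 percentage points lower from compound 2 to compound 3 (within the scatter). Compound 3 is therefore estimated at 100%, within 85% to 105%.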

Compound 3, a percentage reported as inhibition, at one concentration (the size of the read-out at that concentration, not a potency): 100%
Estimate against measurement, compound 3: no gap at the digits printed; measured number inside the range.
By their numbers in this assay, from the lowest: compounds 3, 1 and 2 (each within the scatter of the next).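

In this assay, lengthening the saturated chain by one carbon (a number 2 percentage points lower from compound 2 to compound 3 (within the scatter)) leaves the read-out within the scatter, so this position tolerates that small change at the one concentration tested. The larger change on the aromatic carbon (a number 2 percentage points lower from compound 1 to compound 3 (within the scatter)) also stays within the scatter. Nothing measured here explains this result.

From the compounds shown here alone, whether a much longer chain, or an amine in place of the isothiocyanate at the chain end, would keep this level remains open. One concentration also cannot rank these compounds by potency.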